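The compounds below may be only part of what the source reports. "The series", "measured", "known", "first", "only" and "open" are said of these compounds alone.

In an assay on isolated protein with Bile acid receptor (Homo sapiens) as the target (on this read-out lower numbers stand for an effect already at smaller amounts and higher numbers for an effect only at larger amounts of compound), three compounds have been measured:

Compound 1 `COC(=O)/C=C/c1cccc(N(Cc2ccc(/C=C/c3cccc(C(F)(F)F)c3)cc2)C(=O)C(C)C)c1` gives 267 nM
Compound 2 `COC(=O)/C=C/c1cccc(N(Cc2ccc(/C=C/c3cccc(C(F)(F)F)c3)cc2)C(=O)NC(C)C)c1` gives 932 nM
Compound 3 `COC(=O)/C=C/c1cccc(N(Cc2ccc(-c3c(OC)cccc3OC)cc2)C(=O)C(C)C)c1` gives 95 nM

Compound 3 has the lowest number of the three; the nearest is compound 1, seen in a 2.8-fold lower number from compound 1 to compound 3 (0.45 log units; beyond the scatter), and compound 2 lies furthest away. Compound 4 `COC(=O)/C=C/c1cccc(N(Cc2ccc(-c3c(OC)cccc3OC)cc2)C(=O)NC(C)C)c1` differs from compound 3 in one place: isopropylamino in place of isopropyl on a carbonyl carbon. The same exchange has been measured once before, from compound 1 to compound 2, where it gave a 3.5-fold higher number from compound 1 to compound 2 (0.54 log units; beyond the scatter). Going by the values given here, with only that one step to lean on, compound 4 is expected to show a similar rise, namely a 3.5-fold higher number from compound 3 to compound 4 (0.54 log units; beyond the scatter). For compound 4 the estimated value in this assay is therefore 330 nM, with a range from 150 nM to 750 nM.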

Compound 4, half-maximal effective concentration: 561 nM
Estimate against measurement, compound 4: 1.7-fold (0.23 log units) below; the measured number falls inside the stated range.
By their numbers in this assay, from the lowest: compound 3; then compound 1; then compounds 4 and 2 (each within the scatter of the next).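

Putting isopropylamino in place of isopropyl on the carbonyl carbon also raises the number on a second core (a 5.9-fold higher number from compound 3 to compound 4 (0.77 log units; beyond the scatter)), so this change now has a similar size on both cores: (the same change on two cores in this assay, a 3.5-fold higher number (0.54 log units; beyond the scatter) from compound 1 to compound 2 and a 5.9-fold higher number (0.77 log units; beyond the scatter) from compound 3 to compound 4, 1.7-fold (0.23 log units) apart, within the scatter of two such steps). With isopropylamino on the carbonyl carbon, the 2,6-dimethoxyphenyl exchange gives a smaller step (a 1.7-fold lower number from compound 2 to compound 4 (0.22 log units; within the scatter)), yet the two exchanges still agree: (the same change on two cores in this assay, a 2.8-fold lower number (0.45 log units; beyond the scatter) from compound 1 to compound 3 and a 1.7-fold lower number (0.22 log units; within the scatter) from compound 2 to compound 4, 1.7-fold (0.23 log units) apart, within the scatter of two such steps). Going by these compounds, whether dimethylamino on that carbonyl carbon, which has no amide hydrogen, would raise the number as well remains open, as does the effect of a longer chain there.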